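From a 4-Methylbenzyl to a 3-Chlorobenzyl Group

This account rests on a few compounds, and the source may have more. Where it says the series, first, only, none or still open, it means among the compounds named here.

Measured compounds:
- compound 1, `Cc1cccc(Cn2c(CN3CCN(C(=O)c4cccnc4)CC3)nc3ccccc32)c1`: 24.5%
- compound 2, `Cc1ccc(Cn2c(CN3CCN(C(=O)C4CC4)CC3)nc3ccccc32)cc1`: 51.5%
- compound 3, `Cc1cccc(Cn2c(CN3CCN(C(=O)c4ccc(Cl)cc4)CC3)nc3ccccc32)c1`: 23.2%

Three compounds sharing one core were tested in an assay on isolated protein for inhibition of aldehyde dehydrogenase 1A1 (Homo sapiens), read by spectrophotometry, tested at 10 uM; a higher number here means more inhibition at the concentration tested (going by the name of the read-out), a lower number less inhibition. Compound 2 stands highest of the three; its gaps to compound 1 and to compound 3 are both beyond the scatter, so its inhibition in this assay is the highest in this set. Compound 1 and compound 3 differ only at the carbonyl carbon, and that step, a number 1.3 percentage points lower from compound 1 to compound 3 (within the scatter), lies within the scatter, so the change there left inhibition unchanged.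

Compound 4, `O=C(C1CC1)N1CCN(Cc2nc3ccccc3n2Cc2cccc(Cl)c2)CC1`, has not yet been measured. Compared with compound 2 it carries 3-chlorophenyl in place of 4-methylphenyl on a saturated chain carbon bound to an aromatic nitrogen. For the measured compounds named here, no measured step touches this position: compound 1 and compound 3 carry a different group there as well as a different group on the carbonyl carbon, so their values cannot be separated into two effects. Going by the values given here, the one measured step concerns the carbonyl side and offers no guidance for the change at the saturated chain carbon.

With nothing to go on beyond this, the step of a number 6.5 percentage points lower from compound 2 to compound 4 (within the scatter) is expected to be small and its direction uncertain. Compound 4 is therefore estimated to reach 45% in this assay, within a range of 25% to 65%.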

Compound 4, a percentage reported as inhibition, at one concentration (the size of the read-out at that concentration, not a potency): 71.6%
The estimate for compound 4 lay 26.6 percentage points below the measured number, and the stated range ends below it.
By their numbers in this assay, from the lowest: compounds 3 and 1 (each within the scatter of the next); then compound 2; then compound 4.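

In this assay, for the compounds shown here, the change at the saturated chain carbon bound to an aromatic nitrogen gives a number 20.1 percentage points higher from compound 2 to compound 4 (beyond the scatter), the first measured step at this position, and it shows that the group held there can shift inhibition. The 4-methylphenyl and the 3-chlorophenyl have the same count of heavy atoms, one six-membered aromatic ring each and no hydrogen-bond donors or acceptors, so these counts do not separate two groups that clearly differ in this read-out. Nothing available explains the rise.

The names 4-methylphenyl and 3-chlorophenyl differ in both the substituent and its number, so this single step cannot show which of the two matters; a plain phenyl or a 3-methoxyphenyl at this position would add further points of comparison. As far as these compounds go, it also remains open whether the 3-chlorophenyl would bring a similar rise with the pyridin-3-yl or 4-chlorophenyl on the carbonyl carbon, the groups that compound 1 and compound 3 carry there.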